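Swapping a small ring for a methoxy on the amide carbonyl

The source may hold more compounds than are shown below. What is called first, only, known or untested is meant among the compounds shown, and "the series" means these compounds.

Going by the values given here, the two compounds measured so far share one core and differ only in the acyl group. Compound 1 `C[C@@H]1C[C@@H]1C(=O)N1CC2CNCC2C1` is measured in an assay on SHEP1 cells for displacement of a labelled ligand from Neuronal acetylcholine receptor; alpha4/beta2 (Homo sapiens), read by scintillation counting, with a stated time of 2 h (a higher number here means a weaker inhibitor, a lower number a stronger inhibitor), where compound 1 gives 1 nM, the lowest of the two numbers seen. Compound 2 `C[C@H]1C[C@@H]1C(=O)N1CC2CNCC2C1` gives 43 nM. The step of a 43-fold higher number from compound 1 to compound 2 (1.63 log units; beyond the scatter) is large, and the one thing that can be pointed to for it is the fact that one of compounds 1 and 2 is drawn with a defined configuration and the other without, at the place where they differ: even a change in the spatial arrangement of this small acyl group changes the number a great deal.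

Compound 3 `COC(=O)N1CC2CNCC2C1` keeps the core and the carbonyl but changes what sits on the carbonyl carbon: a group of 2 heavy atoms (1 carbon, 1 oxygen; no ring) in place of a group of 4 heavy atoms (4 carbon; one three-membered non-aromatic ring of carbon only), on a carbonyl carbon. Among the compounds with values here, the only measured step bears on it indirectly, since it shows how sensitive this assay is to the acyl group; replacing that group altogether, with its two defined stereocentres, is a larger change than flipping one centre. The number for compound 3 is therefore expected to be higher, and the expected step is a 30-fold higher number from compound 1 to compound 3 (1.48 log units; beyond the scatter). Compound 3 is estimated at 30 nM, within 5 nM to 200 nM.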

Compound 3, inhibition constant: 23 nM
Beside the measured number, compound 3's estimate is 1.3-fold (0.12 log units) above it; low and high end bracket the measured number.
By their numbers in this assay, from the lowest: compound 1; then compounds 3 and 2 (each within the scatter of the next).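

The methoxy group, with no ring and no defined stereocentres, does not keep the low number of compound 1: in this assay, the swap gives a 23-fold higher number from compound 1 to compound 3 (1.36 log units; beyond the scatter), a large step. Set against the other form of the 2-methylcyclopropyl group, the same methoxy gives a 1.9-fold lower number from compound 2 to compound 3 (0.27 log units; within the scatter), which lies within the scatter, so compounds 2 and 3 cannot be told apart here even though their acyl groups look very different, and compound 1 alone stands out among the three as the strongest inhibitor. Nothing in the available evidence bears on why the methoxy group gives this result, so the step is recorded here without a cause.

These three compounds cannot separate the contribution of the ring from that of its methyl group, since an unsubstituted cyclopropyl on the carbonyl carbon does not appear among them. Nor do they show whether an ethoxy group, a longer carbon chain or an amine in that place would bring the number closer to that of compound 1 or leave it level with compounds 2 and 3.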